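A few compounds are considered here, and "the series" means these few. Any claim that something is new, unique, unknown or untested is made for them only; others in the source may bear on it.

Measured so far:
compound 1 `CCCCCCCc1coc(=O)c(C)c1O` — 2200000 nM
compound 2 `COc1c(CCCC(C)C)coc(=O)c1C` — 2000000 nM

In an ADME assay on MDCK cells (Canis lupus familiaris) for cytotoxicity, read by crystal violet staining, with a stated time of 48 h (on this read-out lower numbers stand for higher toxicity in this test and higher numbers for lower toxicity in this test), compound 1 gives 2200000 nM. In this assay compound 2 gives 2000000 nM, the lowest of the two numbers, with compound 1 as its nearest neighbour at a gap that falls within the scatter of the method. Going by the values given here, no step between measured compounds is available for this pair, so the two values show only that both compounds sit at the same level of low toxicity in this test.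

Compound 3 `COc1c(CCCCC(C)C)coc(=O)c1C` is not yet measured. It differs from compound 2 by isobutyl in place of isopropyl on a saturated chain carbon, three bonds along the chain from an aromatic carbon. The step from compound 2 to compound 3 in this assay is expected to be none beyond the scatter, since nothing in the two measured numbers points either way for a change of this kind. Compound 3 is estimated at 2000000 nM, with a range of 900000 nM to 4500000 nM, which means an expected step of no change at the digits printed from compound 2 to compound 3 (within the scatter).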

Compound 3, half-maximal cytotoxic concentration: 1880000 nM
The estimate for compound 3 lay 1.1-fold (0.03 log units) above the measured number, within the range that was stated.
By their numbers in this assay, from the lowest: compounds 3, 2 and 1 (each within the scatter of the next).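

In this assay, going by these compounds alone, this pair gives the first reading at this position: isobutyl in place of isopropyl on a saturated chain carbon, three bonds along the chain from an aromatic carbon, gives a 1.1-fold lower number from compound 2 to compound 3 (0.03 log units; within the scatter), a step within the scatter. The same difference, cut one bond further out, reads isobutyl to isopentyl, so at this position compound 3 stays at the level of compound 2 in this test. No measured evidence offers an explanation for this result.

Still open, as far as these compounds go, is whether a terminal amine, a carboxylic acid or a much longer chain at this position would give a step beyond the scatter. This single pair covers only an all-carbon change at the end of the chain, and it says nothing about changes elsewhere on the shared core.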